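The compounds below may be only part of what the source reports. "The series", "measured", "known", "first", "only" and "open" are said of these compounds alone.

Compound 1 `CC1=C(C(=O)Nc2ccc(C)cc2)C(c2ccc(O)cc2O)NC(NCc2ccccc2)=N1`: 66700 nM
Compound 2 `CC1=C(C(=O)Nc2ccc(C)cc2)C(c2ccc(O)cc2O)NC(Nc2ccc([N+](=O)[O-])cc2Cl)=N1`: 28200 nM

Among the compounds with values here, in a functional assay on HCT-116 cells (Homo sapiens) for inhibition, read by sulforhodamine B assay, with a stated time of 2 days (a higher number here means a weaker inhibitor of growth, a lower number a stronger inhibitor of growth), compound 2 gives 28200 nM, the lower of the two numbers measured so far, which makes it the stronger growth inhibitor of this pair. The next compound, compound 3 `CC1=C(C(=O)Nc2cccc([N+](=O)[O-])c2)C(c2ccc(O)cc2O)NC(Nc2ccc([N+](=O)[O-])cc2Cl)=N1`, differs from compound 2 in one group: 3-nitrophenyl in place of 4-methylphenyl on an amide-type nitrogen. In short, 3-nitrophenyl takes the place of 4-methylphenyl on an amide-type nitrogen. Within the data shown here, the only measured step, a 2.4-fold lower number from compound 1 to compound 2 (0.37 log units; beyond the scatter), was modest, and it concerns an amine nitrogen, not the amide-type nitrogen changed here. Among the measured compounds shown here, no measurement yet shows what a change at the amide-type nitrogen does, so this step offers only a rough idea of scale. A step of similar or smaller size is therefore expected, leaning slightly towards a lower number, and it may not exceed the scatter. The expected change is a 1.4-fold lower number from compound 2 to compound 3 (0.15 log units; within the scatter). Compound 3 is estimated at 20000 nM, with an expected range of 7000 nM to 55000 nM.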

Compound 3, concentration for 50% growth inhibition: 10900 nM
Compound 3: the middle estimate sits 1.8-fold (0.26 log units) above what was measured, and the stated range covers the measured number.
By their numbers in this assay, from the lowest: compound 3; then compound 2; then compound 1.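

Within the data shown here, this is the first change at the amide-type nitrogen, and in this assay replacing 4-methylphenyl with 3-nitrophenyl gives a 2.6-fold lower number from compound 2 to compound 3 (0.41 log units; beyond the scatter) and so moves the number beyond the usual scatter. The group on this nitrogen therefore affects growth inhibition, at least for this pair, though the step is modest. The swap alters two things at once, methyl becoming nitro and the ring position changing from 4 to 3, and nothing available explains the shift or assigns it to either part.

The compounds shown leave open whether the nitro group or its ring position matters more, a question that 3-methylphenyl or 4-nitrophenyl on the same nitrogen could help settle. On these data alone, it is also open whether the same swap would have a similar effect with benzyl in place of 2-chloro-4-nitrophenyl on the amine nitrogen, and how a ring carrying a carboxylic acid or an amine, or a cyclohexyl group, would fare at the amide-type nitrogen.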